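Sulfone in place of the sulfonamide: expected maximal response

This account rests on a few compounds, and the source may have more. Where it says the series, first, only, none or still open, it means among the compounds named here.

Three measured compounds share one core and differ only in the group on the sulfonyl sulfur. Compound 1 `CC1(C)C=C(n2ccccc2=O)c2cc(S(=O)(=O)Nc3ccccc3)ccc2O1` carries a plain anilino group there; in a functional assay on the whole organism (trachea) with Rattus norvegicus as the target (a higher number here means a larger maximal response, a lower number a smaller maximal response), compound 1 gives 7.85%; 88% (2 entries), two entries that lie far apart (the several entries of compound 1 in this assay, 7.85%; 88% (2 entries)), so no single number stands for it. Compound 2 `CC1(C)C=C(n2ccccc2=O)c2cc(S(=O)(=O)Nc3ccc([N+](=O)[O-])cc3)ccc2O1` carries a (4-nitrophenyl)amino group, and in this assay compound 2 gives 75.6%. Compound 3 `CN(c1ccccc1)S(=O)(=O)c1ccc2c(c1)C(n1ccccc1=O)=CC(C)(C)O2` carries a methyl(phenyl)amino group; in this assay compound 3 gives 86.5%, the highest of the two single numbers. Within the data shown here, the only measured step is a number 10.9 percentage points higher from compound 2 to compound 3 (beyond the scatter), a modest rise beyond the scatter.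

Among the measured compounds shown here, compound 4 `CC1(C)C=C(n2ccccc2=O)c2cc(S(=O)(=O)c3ccccc3)ccc2O1` is the next member. phenyl in place of methyl(phenyl)amino on a sulfonyl sulfur The one measured step changed substituents on the nitrogen; here the nitrogen itself leaves, so that step only loosely bears on the change. Both single numbers, and the upper entry of compound 1, sit in a high band, so compound 4 is expected to remain there, with little or no shift: the step of a number 6.5 percentage points lower from compound 3 to compound 4 (within the scatter) is expected to stay within the scatter. For compound 4 the estimated value in this assay is 80%, with a range from 50% to 95%.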

Compound 4, largest response reached (Emax), in percent of the reference or control that the assay uses: 88.1%
Compound 4: middle estimate off by 8.1 percentage points, on the low side, within the range that was stated.
By their numbers in this assay, from the lowest: compound 2; then compounds 3 and 4 (each within the scatter of the next).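

In this assay, a nitrogen joined to the sulfonyl sulfur turns out not to be required for a high maximal response: with phenyl in place of methyl(phenyl)amino on a sulfonyl sulfur, the result is a number 1.6 percentage points higher from compound 3 to compound 4 (within the scatter), so the two compounds cannot be told apart in this read-out. With the same phenyl in place of (4-nitrophenyl)amino, the result is a number 12.5 percentage points higher from compound 2 to compound 4 (beyond the scatter), which leaves compound 2 as the lowest of the three compounds with a single number, although this gap is only modest. The steps to compound 1 cannot be read, because its entries lie too far apart for any one number to represent it: the several entries of compound 1 in this assay, 7.85%; 88% (2 entries)

On these data alone, all of the compounds with a measured value carry a six-membered aromatic ring of carbon at this place, so it remains open whether a high maximal response would persist with a plain methyl or a longer alkyl chain on the sulfonyl sulfur. As far as these compounds go, it is equally open how a carboxylic acid or an amine on the phenyl ring of compound 4 would behave in this assay.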